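Pyrazole methyl removal on a bulkier diaryl scaffold

The source may hold more compounds than are shown below. What is called first, only, known or untested is meant among the compounds shown, and "the series" means these compounds.

The account begins with compound 1, `Cc1cnn(C(=O)N(C)CCN(C)Cc2ccc(OCc3ccccc3)cc2)c1`, which in an assay on membranes from brain for binding affinity to Monoacylglycerol lipase ABHD6 (Mus musculus), read by fluorescence, with stated times of 1 h and 30 min (a lower number here means a stronger inhibitor, a higher number a weaker inhibitor), gives 1200 nM. Compound 2, `CN(CCN(C)C(=O)n1cccn1)Cc1ccc(OCc2ccccc2)cc1`, gives 530 nM in the same test. For the measured compounds named here, the only change between them is hydrogen in place of methyl on an aromatic carbon, and the result is a 2.3-fold lower number from compound 1 to compound 2 (0.35 log units; beyond the scatter).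

Compound 3, `Cc1cnn(C(=O)N2CCN(C(c3ccc(OCc4ccccc4)cc3)c3ccc(OCc4ccccc4)cc3)CC2)c1`, carries the same methylated five-membered ring on a different core; how its core differs from that of compound 1 is not broken down here. In this assay compound 3 reaches only a limit of the assay, > 100000 nM, which matches (the limit of > 100000 nM in this assay, at which 1 of the 3 values shown sits).

Compound 4, `O=C(N1CCN(C(c2ccc(OCc3ccccc3)cc2)c2ccc(OCc3ccccc3)cc2)CC1)n1cccn1`, has not yet been measured. It stands to compound 3 as compound 2 stands to compound 1: the change is hydrogen in place of methyl on an aromatic carbon, the same change as before. On the core of compound 1 that change gave a 2.3-fold lower number from compound 1 to compound 2 (0.35 log units; beyond the scatter). For compound 4 the expected step is a number no higher from compound 3 to compound 4 (the limit leaves the size open), resting on that earlier step and on the limit seen for compound 3. Compound 4 is therefore estimated at 100000 nM, with a range from 20000 nM to 300000 nM.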

Compound 4, half-maximal inhibitory concentration: > 100000 nM
Compound 4: only a limit was reported; the forecaster's own chance of this, stated with the estimate: 70%; the middle value lies on the limit itself.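

In this assay compound 4 gives > 100000 nM, a limit of the assay, and compound 3 also stands at a limit, so no step can be read between these two compounds: the limit of > 100000 nM in this assay, at which 2 of the 4 values shown sit.

The compounds shown leave open whether going from 4-methyl-1H-pyrazol-1-yl to 1H-pyrazol-1-yl changes the number at all on the core of compound 3.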